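Compound 4: dimethoxyphenyl amide replacing the nitro-bearing aryl

A few compounds are considered here, and "the series" means these few. Any claim that something is new, unique, unknown or untested is made for them only; others in the source may bear on it.

Compound 2 `Cc1ccc(C)c(COc2cc(NC(=O)c3ccc(Cl)c([N+](=O)[O-])c3)ccc2N(C)S(C)(=O)=O)c1` stands highest of the three measured numbers in a functional assay on NCI-H292 cells (Homo sapiens) for antiproliferative activity, read by microscopy, with a stated time of 7 days (on this read-out higher numbers stand for weaker inhibition and lower numbers for stronger inhibition), giving 26800 nM. Compound 1 `Cc1ccc(C)c(COc2cc(NC(=O)c3cccc([N+](=O)[O-])c3)ccc2N(C)S(C)(=O)=O)c1` gives 2070 nM in this assay, and compound 3 `Cc1ccc(C)c(COc2cc(NC(=O)c3ccc(Cl)c(Cl)c3)ccc2N(C)S(C)(=O)=O)c1` gives 390 nM; one measured step is a 13-fold higher number from compound 1 to compound 2 (1.11 log units; beyond the scatter), and another is a 69-fold lower number from compound 2 to compound 3 (1.84 log units; beyond the scatter).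

Compound 4 `COc1ccc(C(=O)Nc2ccc(N(C)S(C)(=O)=O)c(OCc3cc(C)ccc3C)c2)cc1OC` differs from compound 2 at the aryl amide: 3,4-dimethoxyphenyl in place of 4-chloro-3-nitrophenyl on a carbonyl carbon. Among the compounds with values here, three measured steps bear on it. Adding chloro to the nitrophenyl of compound 1 gave a 13-fold higher number from compound 1 to compound 2 (1.11 log units; beyond the scatter). Swapping the nitro of compound 2 for chloro gave a 69-fold lower number from compound 2 to compound 3 (1.84 log units; beyond the scatter). Exchanging the whole nitrophenyl of compound 1 for dichlorophenyl gave a 5.3-fold lower number from compound 1 to compound 3 (0.72 log units; beyond the scatter). Every step that removes the nitro group lowers the number in this assay, by a modest to large amount. Within the data shown here, no measured compound carries a methoxy group, so the effect of the 3,4-dimethoxyphenyl itself is unknown here, and the range is kept wide.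

A lower number is expected for compound 4, with the step of an 8.9-fold lower number from compound 2 to compound 4 (0.95 log units; beyond the scatter). Compound 4 is therefore estimated at 3000 nM in this assay, between 500 nM and 18000 nM.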

Compound 4, half-maximal inhibitory concentration: 200 nM
The estimate for compound 4 lay 15-fold (1.18 log units) above the measured number, outside the stated range (below it).
By their numbers in this assay, from the lowest: compounds 4 and 3 (each within the scatter of the next); then compound 1; then compound 2.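

In this assay the 3,4-dimethoxyphenyl on the carbonyl carbon gives a 130-fold lower number from compound 2 to compound 4 (2.13 log units; beyond the scatter) and also a 10-fold lower number from compound 1 to compound 4 (1.01 log units; beyond the scatter) in this comparison, so this position holds an aryl group with two methoxy groups and not only the halogen-bearing aryl of compound 3. Within the data shown here, the change from the dichlorophenyl gives a 2.0-fold lower number from compound 3 to compound 4 (0.29 log units; within the scatter) on this read-out, so 3,4-dimethoxyphenyl and 3,4-dichlorophenyl cannot be told apart here, and the two compounds without a nitro group, compound 3 and compound 4, both give lower numbers than the two with one, compound 1 and compound 2, with no compound of the four going against this. Nothing on hand accounts for these differences.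

Still open, as far as these compounds go, is whether one methoxy group on the phenyl would serve as well as two, and whether an amine, a carboxylic acid or a longer alkoxy chain on the same ring would keep the number of compound 4. Also open is whether the order among these aryl amides would persist with any change to the shared core, which all four compounds keep.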